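This account rests on a few compounds, and the source may have more. Where it says the series, first, only, none or still open, it means among the compounds named here.

In a functional assay on CAKI-1 cells (Homo sapiens) for cytotoxicity, read by sulforhodamine B assay, with a stated time of 48 h (a lower number here means a stronger inhibitor of growth, a higher number a weaker inhibitor of growth), compound 1 `ClCc1ccc(Cn2cnc3c(Cl)ncnc32)cc1` gives 260 nM and compound 2 `ClCc1ccccc1Cn1cnc2c(Cl)nc(Cl)nc21` gives 360 nM. Compound 2 thus holds the higher of the two numbers, with compound 1 its nearest neighbour at a gap within the scatter. Compound 3 `ClCc1ccccc1Cn1cnc2c(Cl)ncnc21` is reached from compound 2 by hydrogen in place of chloro on an aromatic carbon. Within the data shown here, no measured pair isolates this change. Given that the two numbers shown sit within the scatter of each other, the step expected a 1.2-fold lower number from compound 2 to compound 3 (0.08 log units; within the scatter) is none beyond the scatter. Compound 3 is therefore estimated at 300 nM, with a range of 120 nM to 800 nM.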

Compound 3, concentration for 50% growth inhibition: 1820 nM
Estimate against measurement, compound 3: 6.1-fold (0.78 log units) below, outside the stated range (above it).
By their numbers in this assay, from the lowest: compounds 1 and 2 (each within the scatter of the next); then compound 3.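

In this assay, hydrogen in place of the chloro on the aromatic carbon between two ring nitrogen atoms gives a 5.1-fold higher number from compound 2 to compound 3 (0.70 log units; beyond the scatter) and so a weaker inhibitor of growth. This single-place step shows that the position is not silent and that, within this pair, the chloro is the better of the two substituents. No measurement on hand accounts for the step. From the compounds shown here alone, whether an amine, a methoxy group or fluoro at this position would match the chloro of compound 2 stays open. So does whether the step holds with the chloromethyl group placed as in compound 1.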